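Swapping Bromine for Chlorine on a Shared Hydroxamic Acid Core

A few compounds are considered here, and "the series" means these few. Any claim that something is new, unique, unknown or untested is made for them only; others in the source may bear on it.

Of the compounds shown here, three with a shared core have been measured in an assay on Sf9 cells for inhibition of protein deacetylase HDAC6 (Homo sapiens), read by fluorescence, with a stated time of 40 min, tested at 100 nM; a lower number here means less inhibition, a higher number more inhibition at the concentration tested (going by the name of the read-out). Compound 1 `O=C(NO)c1ccc(NCc2nc(-c3ccccc3)nn2-c2cccc(Cl)c2)cc1` gives 62.3%. Compound 3 `Cc1ccc(-n2nc(-c3ccccc3)nc2CNc2ccc(C(=O)NO)cc2)cc1C` carries a 3,4-dimethylphenyl in place of the 3-chlorophenyl on an aromatic nitrogen and gives 53%. The step of a number 9.3 percentage points lower from compound 1 to compound 3 (within the scatter) lies within the scatter. Compound 2 `O=C(NO)c1ccc(NCc2nc(-c3ccc(Br)cc3)nn2-c2ccccc2)cc1` gives 54.7% in this assay; its number lies between those of compound 1 and compound 3, and all three values are within the usual scatter of one another, so no order among them can be read.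

Compound 4 `O=C(NO)c1ccc(NCc2nc(-c3ccc(Cl)cc3)nn2-c2ccccc2)cc1` differs from compound 2 by a single change: chloro in place of bromo on an aromatic carbon. Among the measured compounds shown here, no measured step touches this place. For the measured compounds named here, the only measured step, a number 9.3 percentage points lower from compound 1 to compound 3 (within the scatter), alters the ring on the aromatic nitrogen and was itself within the scatter. Nothing in the data therefore points to movement in this assay beyond the scatter, in either direction. Compound 4 is expected to give about 54%, in a range from 40% to 68%. This corresponds to an expected step of a number 0.7 percentage points lower from compound 2 to compound 4 (within the scatter).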

Compound 4, a percentage reported as inhibition, at one concentration (the size of the read-out at that concentration, not a potency): 67.2%
For compound 4 the middle estimate is 13.2 percentage points below the measured one, and the stated range covers the measured number.
By their numbers in this assay, from the lowest: compounds 3, 2, 1 and 4 (each within the scatter of the next, the first and the last beyond it).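

The exchange of bromo for chloro on an aromatic carbon, para to a large group, is small: one heavy atom replaces one heavy atom, and the counted hydrogen-bond donors, acceptors and charge stay the same. Even so, in this assay it gives a number 12.5 percentage points higher from compound 2 to compound 4 (beyond the scatter) and is the only step shown so far to pass the usual scatter, so this position is not silent to a change of halogen. Nothing available explains why this exchange moves the number.

As far as these compounds go, with only these two halogens compared here, it remains open how fluoro, a methoxy group or an amine would read at this place. From the compounds shown here alone, it is also open whether the same exchange would give a similar step on the ring attached to the aromatic nitrogen.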